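The compounds below may be only part of what the source reports. "The series", "measured", "known", "first", "only" and "open" are said of these compounds alone.

In a functional assay on Z-138 cells (Homo sapiens) for antiproliferative activity, with a stated time of 72 h (on this read-out higher numbers stand for weaker inhibition and lower numbers for stronger inhibition), compound 1 `CCCCC#Cc1cc([C@@H]2O[C@H](CO)[C@@H](O)[C@H]2O)n2ncnc(N)c12` gives 200 nM. Compound 2 `Nc1ncnn2c([C@@H]3O[C@H](CO)[C@@H](O)[C@H]3O)cc(-c3ccccc3)c12` gives > 100000 nM, which is a limit of the assay and not a number. That puts compound 2 at the limit of > 100000 nM in this assay, at which 1 of the 2 values shown sits. Compound 3 `Nc1ncnn2c([C@@H]3O[C@H](CO)[C@@H](O)[C@H]3O)cc(-c3ccc(F)cc3)c12` differs from it by fluoro in place of hydrogen on an aromatic carbon. For the measured compounds named here, the only measured step, an at least 500-fold higher number from compound 1 to compound 2 (2.69 log units; beyond the scatter), was large, but it swapped a whole group at another place, so it is only a loose guide. In this assay no change beyond the scatter is therefore expected. The expected change is a number no higher from compound 2 to compound 3 (the limit leaves the size open). For compound 3 the estimated value is 100000 nM, with an expected range of 30000 nM to 200000 nM.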

Compound 3, half-maximal inhibitory concentration: > 100000 nM
Compound 3 ended at the assay's limit; the forecaster's own chance of this, stated with the estimate: 75%; the middle value sits exactly at the limit.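

At this place on the shared core, a para fluoro on the phenyl ring does not bring back what the hex-1-yn-1-yl group of compound 1 gave: in this assay there is an at least 500-fold higher number from compound 1 to compound 3 (2.69 log units; beyond the scatter). The step between compound 2 and compound 3 cannot be read, as both values are limits of the assay, so any effect of the fluoro stays hidden. Phenyl and 4-fluorophenyl now stand at the same ceiling: the limit of > 100000 nM in this assay, at which 2 of the 3 values shown sit.

Still open, from the compounds shown here alone, is how an amine or a shorter alkyne chain at this place would fare. Also open, going by these compounds, is whether a small group on the phenyl ring other than fluoro could lift compounds of this kind off the limit.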